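The source may hold more compounds than are shown below. What is called first, only, known or untested is meant among the compounds shown, and "the series" means these compounds.

Measured so far: compound 1 `O=C(CCc1ccc(-c2ccccc2)cc1)c1ncc(-c2cccnc2)o1` gives 1.1 nM; compound 2 `COC(=O)c1cccc(-c2cnc(C(=O)CCc3ccc(OC4CCN(C(=O)OC(C)(C)C)CC4)cc3)o2)n1` gives 32 nM; compound 3 `O=C(O)c1ccc(-c2cnc(CCCc3ccc(-c4ccccc4)cc3)o2)nc1` gives 20000 nM, all in an assay for inhibition of Fatty-acid amide hydrolase 1 (Rattus norvegicus); a lower number here means a stronger inhibitor, a higher number a weaker inhibitor.

Compound 1 holds the lowest number of the three; its gap to compound 2 lies beyond the scatter, and its gap to compound 3 is far wider still. Compound 4 `CN(C)C(=O)c1cnc(C(=O)CCc2ccc(-c3ccccc3)cc2)o1` keeps the ketone, the linker and the biphenyl tail of compound 1 and differs in one place: dimethylcarbamoyl in place of pyridin-3-yl on an aromatic carbon. Within the data shown here, no measured pair isolates this change, so the size of the step rests on judgement. Among the measured compounds shown here, since the non-aromatic replacement has no precedent among the measured compounds, compound 4 is expected to give a higher number, with a step of a 27-fold higher number from compound 1 to compound 4 (1.44 log units; beyond the scatter). The estimate for compound 4 in this assay is 30 nM, within a range from 5 nM to 200 nM.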

Compound 4, inhibition constant: 3 nM
For compound 4 the middle estimate is 10-fold (1.00 log units) above the measured one, and the stated range ends above it.
By their numbers in this assay, from the lowest: compound 1; then compound 4; then compound 2; then compound 3.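

In this assay, dimethylcarbamoyl in place of pyridin-3-yl on this aromatic carbon, next to the ring oxygen, gives a 2.7-fold higher number from compound 1 to compound 4 (0.44 log units; beyond the scatter), a modest step. For this pair, then, a group with no ring at this place still leaves compound 4 at 3 nM, so an aromatic ring here is not needed for a low number. Nothing measured here gives a reason for the size of this step. The compounds shown leave open whether a primary carboxamide or a simple amine at this place would hold the number as well.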